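The source may hold more compounds than are shown below. What is called first, only, known or untested is meant among the compounds shown, and "the series" means these compounds.

In a functional assay on DU-145 cells (Homo sapiens) for inhibition, read by trypan blue exclusion, with a stated time of 96 h (on this read-out higher numbers stand for weaker inhibition of growth and lower numbers for stronger inhibition of growth), compound 1 `Cc1ccc(S/C(=C/c2ccc(N(C)C)cc2)C(=O)c2ccc(Cl)cc2)cc1` gives only a limit, > 100000 nM. Compound 2 `COc1ccc(/C=C(/Sc2ccc(C)cc2)C(=O)c2ccc(Cl)cc2)cc1O` in this assay gives 1000 nM. The change from compound 1 to compound 2 is 3-hydroxy-4-methoxyphenyl in place of 4-(dimethylamino)phenyl on a double-bonded chain carbon bound to a double-bonded chain carbon, and it made an at least 100-fold lower number from compound 1 to compound 2 (2.00 log units; beyond the scatter). Compound 3 `CN(C)c1ccc(/C=C(\C(=O)c2ccc(Cl)cc2)S(=O)(=O)c2ccc(Br)cc2)cc1` differs from compound 1 in its core by (4-bromophenyl)sulfonyl in place of (4-methylphenyl)sulfanyl on a double-bonded chain carbon bound to a carbonyl carbon and a double-bonded chain carbon. In this assay compound 3 gives only a limit, > 100000 nM. The step that the two limits leave unreadable from compound 1 to compound 3 cannot be read because of the limit of > 100000 nM in this assay, at which 2 of the 3 values shown sit. Compound 4 `COc1ccc(/C=C(\C(=O)c2ccc(Cl)cc2)S(=O)(=O)c2ccc(Br)cc2)cc1O` has not been measured in this assay; it stands to compound 3 as compound 2 stands to compound 1, through the same change, (3-hydroxy-4-methoxyphenyl in place of 4-(dimethylamino)phenyl on a double-bonded chain carbon bound to a double-bonded chain carbon). From compound 3 to compound 4 a step of an at least 20-fold lower number from compound 3 to compound 4 (1.30 log units; beyond the scatter) is expected, resting on compound 1, where the same change made an at least 100-fold lower number from compound 1 to compound 2 (2.00 log units; beyond the scatter). Compound 4 is thus estimated at 5000 nM, between 800 nM and 100000 nM.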

Compound 4, concentration for 50% growth inhibition: 10000 nM
Compound 4: the middle estimate sits 2.0-fold (0.30 log units) below what was measured, within the range that was stated.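

In this assay, 3-hydroxy-4-methoxyphenyl in place of 4-(dimethylamino)phenyl also lowers the number on the core of compound 3, with an at least 10-fold lower number from compound 3 to compound 4 (1.00 log units; beyond the scatter). The change therefore points the same way on both cores, but this does not show that it carries over with the same size: the same change on two cores in this assay, an at least 100-fold lower number (2.00 log units; beyond the scatter) from compound 1 to compound 2 and an at least 10-fold lower number (1.00 log units; beyond the scatter) from compound 3 to compound 4; the limit leaves it open whether they differ. With 3-hydroxy-4-methoxyphenyl in place, (4-bromophenyl)sulfonyl in place of (4-methylphenyl)sulfanyl gives a 10-fold higher number from compound 2 to compound 4 (1.00 log units; beyond the scatter), whereas the matching step with 4-(dimethylamino)phenyl cannot be read: the limit of > 100000 nM in this assay, at which 2 of the 4 values shown sit.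

The compounds shown leave open how the hydroxy and methoxy groups each contribute when present alone. They also leave open whether an amine or a carboxylic acid in place of 3-hydroxy-4-methoxyphenyl would behave alike on the two cores.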